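The source may hold more compounds than are shown below. What is called first, only, known or untested is meant among the compounds shown, and "the series" means these compounds.

Compound 2, `NC(=O)[C@@H]1CCN1Cc1ccc(OCc2cccc(F)c2)cc1Cl`, gives 35 nM in an assay on Sf9 cells for inhibition of Amine oxidase [flavin-containing] B (Homo sapiens), with stated times of 15 min and 60 min (a lower number here means a stronger inhibitor, a higher number a weaker inhibitor), and compound 1, `Cc1cc(OCc2cccc(F)c2)ccc1CN[C@@H](C)C(N)=O`, gives 69 nM in this assay; the two numbers lie within the usual scatter of each other, so neither can be called the stronger. Compound 3, `C[C@H](NCc1ccc(OCc2cccc(F)c2)cc1Cl)C(N)=O`, carries (1-carbamoylethyl)amino in place of 2-carbamoylazetidin-1-yl on a saturated chain carbon bound to an aromatic carbon. Compound 1 already holds the (1-carbamoylethyl)amino group on the same kind of carbon, and its value stands close to that of compound 2, so compound 3 is expected to show no step beyond the scatter, a 1.4-fold higher number from compound 2 to compound 3 (0.15 log units; within the scatter). Compound 3 is thus estimated at 50 nM, within a range from 20 nM to 125 nM.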

Compound 3, half-maximal inhibitory concentration: 28 nM
Estimate against measurement, compound 3: 1.8-fold (0.25 log units) above; low and high end bracket the measured number.
By their numbers in this assay, from the lowest: compounds 3, 2 and 1 (each within the scatter of the next, the first and the last beyond it).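

In this assay, (1-carbamoylethyl)amino in place of 2-carbamoylazetidin-1-yl on a saturated chain carbon bound to an aromatic carbon gives a 1.3-fold lower number from compound 2 to compound 3 (0.10 log units; within the scatter), so these two compounds do not tell the open chain from the four-membered ring. Among the compounds shown here, with (1-carbamoylethyl)amino held fixed, chloro in place of methyl on an aromatic carbon gives a 2.5-fold lower number from compound 1 to compound 3 (0.39 log units; beyond the scatter), the only modest step here that lies beyond the scatter. Nothing available accounts for either step. From the compounds shown here alone, whether bromo or methoxy on that aromatic carbon would shift the number remains open, as does the effect of a carboxylic acid in place of the carbamoyl group.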